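This account rests on a few compounds, and the source may have more. Where it says the series, first, only, none or still open, it means among the compounds named here.

Notes on the series. Compound 3 `O=c1c(-c2ccc(O)cc2)coc2cc(OCCCCCCCCCCCCO)ccc12` carries an 8-hydroxyoctyl chain and is the weakest of the three measured analogues in an assay (Cricetulus griseus) for inhibition of aldehyde dehydrogenase, mitochondrial (Homo sapiens) (a lower number here means a stronger inhibitor, a higher number a weaker inhibitor), where compound 3 gives 1700 nM. Compound 1 `CCOC(=O)CCCCOc1ccc2c(=O)c(-c3ccc(O)cc3)coc2c1`, the ethoxycarbonyl analogue, gives 240 nM in this assay, and compound 2 `O=C(O)CCCCCCCCCCCOc1ccc2c(=O)c(-c3ccc(O)cc3)coc2c1`, the long carboxy-terminated analogue, gives 130 nM. The step of a 7.1-fold higher number from compound 1 to compound 3 (0.85 log units; beyond the scatter) is modest, and the step of a 13-fold higher number from compound 2 to compound 3 (1.12 log units; beyond the scatter) is large, whereas a 1.8-fold lower number from compound 1 to compound 2 (0.27 log units; within the scatter) stays within the scatter.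

Compound 4 `O=C(O)CCCCCCOc1ccc2c(=O)c(-c3ccc(O)cc3)coc2c1` is the next point. The change from compound 3 is carboxy in place of 6-hydroxyhexyl on a saturated chain carbon, six bonds along the chain from an oxygen on an aromatic ring. The step bearing most directly on it is a 13-fold higher number from compound 2 to compound 3 (1.12 log units; beyond the scatter), since compound 4 carries the carboxy end of compound 2 on a shorter chain; run in reverse, that step points to a large drop in the number. Within the data shown here, the chain is shortened at the same time, and the only guide there is a 1.8-fold lower number from compound 1 to compound 2 (0.27 log units; within the scatter), which lies within the scatter. Compound 4 is therefore expected to give a number well below that of compound 3, near the values of compound 1 and compound 2, with the step estimated as an 8.5-fold lower number from compound 3 to compound 4 (0.93 log units; beyond the scatter). The estimate for compound 4 in this assay is 200 nM, with a range from 80 nM to 500 nM.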

Compound 4, half-maximal inhibitory concentration: 50 nM
Compound 4: the middle estimate sits 4.0-fold (0.60 log units) above what was measured; measured number outside the range, below it.
By their numbers in this assay, from the lowest: compound 4; then compounds 2 and 1 (each within the scatter of the next); then compound 3.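

Among the two carboxy-ended chains, length now registers in this assay: the shorter chain gives a 2.6-fold lower number from compound 2 to compound 4 (0.41 log units; beyond the scatter), a reading that the earlier comparison of compound 1 with compound 2, which stayed within the scatter, could not supply. The separation of the ester end from the free carboxy end also becomes visible at this position, with a 4.8-fold lower number from compound 1 to compound 4 (0.68 log units; beyond the scatter), although chain length differs in this pair too. Compound 4 also stands well apart from the hydroxy-ended chain, with a 34-fold lower number from compound 3 to compound 4 (1.53 log units; beyond the scatter), and its steps to all three earlier compounds lie beyond the scatter, making it the strongest inhibitor of the four. No supporting measurement is available to explain these differences.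

End group and chain length change together in the step from compound 3 to compound 4, so their separate contributions remain unresolved, and a hydroxy-ended chain of the same length as in compound 4 would be needed to separate them. Also open, on these data alone, is whether a carboxylic acid on a still shorter chain, or a primary amide or tetrazole at the chain end, would keep or lower the number.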